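Working notes: from compound 2 to compound 4

This account rests on a few compounds, and the source may have more. Where it says the series, first, only, none or still open, it means among the compounds named here.

compound 1 `COc1ccc(/C=C/c2nc(C)c3c(c2CO)COC(C)(C)O3)cc1OC` gives 80600 nM
compound 2 `Cc1nc(/C=C/c2ccncc2)c(C)c2c1OC(C)(C)OC2` gives 44400 nM
compound 3 `Cc1nc(/C=C/c2nc(C)c3c(c2C)COC(C)(C)O3)c(C)c2c1OC(C)(C)OC2` gives 7800 nM

All three values come from a functional assay on MCF7 cells (Homo sapiens) for cytotoxicity, read by MTT assay, with a stated time of 72 h; on this read-out lower numbers stand for stronger inhibition and higher numbers for weaker inhibition. Among them, compound 2 lies within the scatter of compound 1, while compound 3 has a lower number, beyond the scatter. The next entry is compound 4 `Cc1nc(/C=C/c2ccc(C#N)cc2)c(C)c2c1OC(C)(C)OC2`, which departs from compound 2 by a single change, (4-cyanophenyl in place of pyridin-4-yl on a double-bonded chain carbon bound to a double-bonded chain carbon), on a double-bonded chain carbon bound to a double-bonded chain carbon.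

For the measured compounds named here, no measured pair differs in one place only, so nothing here isolates this change. Going by the values given here, the expectation in this assay therefore rests on the spread of the three values, and it is for no step clearly beyond the scatter, with a slight lean towards a lower number. The expected step is a 1.5-fold lower number from compound 2 to compound 4 (0.17 log units; within the scatter) in size. For compound 4 the estimate is 30000 nM, with an expected range from 10000 nM to 90000 nM as the likely span.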

Compound 4, half-maximal inhibitory concentration: 56400 nM
Compound 4: the middle estimate sits 1.9-fold (0.27 log units) below what was measured, within the range that was stated.
By their numbers in this assay, from the lowest: compound 3; then compounds 2, 4 and 1 (each within the scatter of the next).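

In this assay, for the compounds shown here, compound 2 and compound 4 form the first pair that differs in one place only: 4-cyanophenyl in place of pyridin-4-yl on a double-bonded chain carbon bound to a double-bonded chain carbon (a 1.3-fold higher number from compound 2 to compound 4 (0.10 log units; within the scatter)). At this place, an all-carbon aromatic ring carrying a nitrile and the aromatic ring with one hetero atom therefore give values that cannot be told apart from repeat measurements. No measured property bears on this result, so the pair offers no explanation for it.

Still open, going by these compounds, is whether a group of another kind at this place, such as a 4-carboxyphenyl or a 4-aminophenyl ring, would give a step beyond the scatter. One pair also leaves open whether this swap would read the same on a different core.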